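The compounds below may be only part of what the source reports. "The series", "measured", "known", "first", "only" and "open" are said of these compounds alone.

In an ADME assay on L02 cells (Homo sapiens) for cytotoxicity, read by MTT assay, with a stated time of 24 h (a higher number here means that more compound is tolerated, a lower number that less compound is tolerated), the compounds share one core and differ only in the ring that hangs from the five-membered aromatic ring with three nitrogens. Among the compounds with values here, compound 1 `Cc1ccc(-n2cc(-c3cccc(NS(=O)(=O)c4c[nH]c(=O)[nH]c4=O)c3)nn2)cc1` carries a methylphenyl there and gives 23100 nM, the one number so far. Compound 2 `O=c1[nH]cc(S(=O)(=O)Nc2cccc(-c3cn(-c4ccccc4F)nn3)c2)c(=O)[nH]1` carries a 2-fluorophenyl and is recorded in this assay as "not toxic" (no number reported), with no number. Compound 3 `O=c1[nH]cc(S(=O)(=O)Nc2cccc(-c3cn(-c4ccc(F)cc4)nn3)c2)c(=O)[nH]1` carries a 4-fluorophenyl and is likewise recorded in this assay as "not toxic" (no number reported), so its standing cannot be placed against compound 1 on a scale; it is known only that no half-maximal cytotoxic concentration was reached. Compound 4 `O=c1[nH]cc(S(=O)(=O)Nc2cccc(-c3cn(-c4ccccc4Cl)nn3)c2)c(=O)[nH]1` is the next step: 2-chlorophenyl in place of 4-fluorophenyl on an aromatic nitrogen. Within the data shown here, no measured pair of this kind exists here, so the size of the step in this assay is unknown; nothing in the three measured compounds points to a move beyond the scatter in either direction. Compound 4 is expected to be tolerated at roughly 40000 nM, within a range of 15000 nM to 120000 nM, and it may well come back without a number, as compound 3 did.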

Compound 4, half-maximal cytotoxic concentration: 11500 nM
The estimate for compound 4 lay 3.5-fold (0.54 log units) above the measured number; measured number below the stated range.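

In this assay, putting 2-chlorophenyl in place of 4-methylphenyl on the aromatic nitrogen gives a 2.0-fold lower number from compound 1 to compound 4 (0.30 log units; within the scatter) and so does not separate these two groups. Compound 4 is the second compound here with a measured half-maximal cytotoxic concentration, whereas compound 2 and compound 3, which carry a fluorophenyl at this position, are recorded only as not toxic, so the steps involving those two cannot be read. No measurement shown here explains why a number was obtained with one group on this nitrogen and not with another. Every group shown at this position is a substituted phenyl ring, so the effect of a carboxylic acid, an amine or a longer chain remains open. From the compounds shown here alone, whether compound 2 and compound 3 are truly better tolerated than compound 4 also remains open without numbers for them.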